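Benzoyl for carbamoyl on the shared core

This account rests on a few compounds, and the source may have more. Where it says the series, first, only, none or still open, it means among the compounds named here.

Compound 2 `N#C/C(=C\N1CCN(C(=O)c2ccco2)C1=S)C(N)=O` gives 35600 nM in a functional assay on PC-3 cells (Homo sapiens) for inhibition, read by sulforhodamine B assay, with a stated time of 48 h (a higher number here means a weaker inhibitor of growth, a lower number a stronger inhibitor of growth), the highest of the two numbers shown, though compound 1 `N#C/C(=C\N1CCN(C(=O)c2ccco2)C1=S)C(=O)Nc1ccc(Cl)cc1` with 18900 nM lies within the scatter of it, the step being a 1.9-fold higher number from compound 1 to compound 2 (0.27 log units; within the scatter). Compound 3 `N#C/C(=C\N1CCN(C(=O)c2ccco2)C1=S)C(=O)c1ccccc1` carries phenyl in place of amino on a carbonyl carbon, read one bond further out as carbamoyl to benzoyl. Within the data shown here, only that one measured step bears on this change, and it stayed within the scatter, so in this assay no step beyond the scatter is expected, at most a slightly lower number, an expected step of a 1.6-fold lower number from compound 2 to compound 3 (0.21 log units; within the scatter). For compound 3 the estimate is 22000 nM, range 7000 nM to 60000 nM.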

Compound 3, concentration for 50% growth inhibition: 31700 nM
Beside the measured number, compound 3's estimate is 1.4-fold (0.16 log units) below it, and the stated range covers the measured number.
By their numbers in this assay, from the lowest: compounds 1, 3 and 2 (each within the scatter of the next).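

Among these compounds, replacing the nitrogen on the carbonyl carbon with a phenyl ring gives the first member without a nitrogen at this place, and in this assay the number does not leave the scatter in either comparison (a 1.1-fold lower number from compound 2 to compound 3 (0.05 log units; within the scatter)) and (a 1.7-fold higher number from compound 1 to compound 3 (0.22 log units; within the scatter)). The amino, (4-chlorophenyl)amino and phenyl groups therefore cannot be told apart here, and neither the amide hydrogen nor the nitrogen link shows any effect. No evidence on hand accounts for this.
Still open, on these data alone, is whether a carboxylic acid, a longer alkyl chain or a cyclic amine on this carbonyl carbon would give a step beyond the scatter.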